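The source may report more compounds than this note shows. Statements on the series, on what has been measured and on what is new or still open speak of the compounds shown alone.

Measured compounds:
compound 1 `Cc1cc(C)c(NC(=O)c2sccc2S(=O)(=O)Nc2onc(C)c2Cl)c(C)c1C#N`: 37200 nM
compound 2 `CCCS(=O)(=O)c1cc(C)cc(C)c1NC(=O)c1sccc1S(=O)(=O)Nc1onc(C)c1Cl`: 5450 nM

In an in vivo ADME assay on the whole organism (plasma) for pharmacokinetics, with Rattus norvegicus as the target, at a dose of 50 mg/kg by the oral route (on this read-out higher numbers stand for higher exposure at the dose given and lower numbers for lower exposure), compound 2 gives 5450 nM, the lower of the two numbers, while compound 1 gives 37200 nM, a gap that lies beyond the scatter. Compound 3 `CO/N=C(\C)c1cc(C)cc(C)c1NC(=O)c1sccc1S(=O)(=O)Nc1onc(C)c1Cl` has not yet been measured. It differs from compound 2 in one place: a group of 5 heavy atoms (3 carbon, 1 nitrogen, 1 oxygen; no ring) in place of a group of 6 heavy atoms (3 carbon, 2 oxygen, 1 sulfur; no ring), on an aromatic carbon. Within the data shown here, no measured pair shows this same change, so there is no step to lean on; compound 1 differs from compound 2 in more than one place and only shows that this ring position tolerates other groups with higher exposure. The author expects compound 3 to move upward from compound 2 by a step of a 2.0-fold higher number from compound 2 to compound 3 (0.30 log units; within the scatter) in this assay, possibly beyond the scatter but not certainly. The estimate for compound 3 in this assay is 11000 nM, within the range 3500 nM to 34000 nM.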

Compound 3, maximal plasma concentration: 27800 nM
Beside the measured number, compound 3's estimate is 2.5-fold (0.40 log units) below it; the range from low to high includes it.
By their numbers in this assay, from the lowest: compound 2; then compounds 3 and 1 (each within the scatter of the next).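

The change gives this position its first step of its own: in this assay, putting the open-chain group of 5 heavy atoms in place of propylsulfonyl gives a 5.1-fold higher number from compound 2 to compound 3 (0.71 log units; beyond the scatter). The rise comes with no shift in the counted hydrogen-bond donors, hydrogen-bond acceptors or net charge, and neither group has a ring, while the entering group has one double bond fewer outside aromatic rings and carries nitrogen instead of sulfur. Nothing measured here accounts for the rise.

On these data alone, it remains open whether the step follows from losing the sulfonyl or from the particular group that enters. A methylsulfonyl group, a simple acetyl group or a longer ether chain on the nitrogen-bound oxygen could help separate these two readings at this position.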